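The source may hold more compounds than are shown below. What is called first, only, known or untested is meant among the compounds shown, and "the series" means these compounds.

Measured so far:
compound 1, `[N-]=[N+]=Nc1nc2c(N)ncnc2n1[C@@H]1O[C@@H]2COP(=O)(O)O[C@H]2[C@H]1O`: 227%
compound 2, `Nc1ncnc2c1nc(S)n2[C@@H]1O[C@@H]2COP(=O)(O)O[C@H]2[C@H]1O`: 136%

Going by the values given here, in a functional assay on the whole organism for activation, with Mus musculus as the target, with stated times of 14 days and 2 h, at a dose of 6 mg/kg by the intravenous route (on this read-out higher numbers stand for a stronger effect at the one dose given and lower numbers for a weaker effect), compound 2 stands lowest of the two numbers; its nearest neighbour is compound 1, and the one measured step between them, a number 91 percentage points lower from compound 1 to compound 2 (beyond the scatter), came from sulfanyl in place of azido on an aromatic carbon. Compound 3, `Nc1ncnc2c1nc(SCc1ccccc1)n2[C@@H]1O[C@@H]2COP(=O)(O)O[C@H]2[C@H]1O`, has not yet been measured in this assay. It differs from compound 2 by benzyl in place of hydrogen on a sulfur. Among the compounds with values here, no measured step touches the sulfur or adds a benzyl, so the only known step, a number 91 percentage points lower from compound 1 to compound 2 (beyond the scatter), bears on it loosely: it shows that a change at this part of the shared core can move the number by a large amount, but it gives no direction for the present change. Without a closer guide, no step beyond the scatter is expected, and the margin is kept wide. In this assay compound 3 is therefore expected to give 150%, between 70% and 260%. The step this estimate means, a number 14 percentage points higher from compound 2 to compound 3 (beyond the scatter), is expected to be small.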

Compound 3, a percentage reported as activity, at one dose (the size of the read-out at that dose, not a potency): 135%
The estimate for compound 3 lay 15 percentage points above the measured number, and the stated range covers the measured number.
By their numbers in this assay, from the lowest: compounds 3 and 2 (each within the scatter of the next); then compound 1.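

In this assay, benzyl in place of hydrogen on the sulfur gave a number 1 percentage points lower from compound 2 to compound 3 (within the scatter) (within the scatter), so at this position the added benzyl, with its six-membered aromatic ring, leaves the read-out unchanged. Benzylsulfanyl in place of azido gave a number 92 percentage points lower from compound 1 to compound 3 (beyond the scatter) and sulfanyl in place of azido gave a number 91 percentage points lower from compound 1 to compound 2 (beyond the scatter) in the same assay, so the large gap to the azido compound appears with or without the benzyl on the sulfur. No evidence is available on why these numbers fall as they do.

On these data alone, whether other groups on the sulfur, such as methyl, a longer chain or a chain ending in a carboxylic acid, would also match the sulfanyl compound remains open. So does the result of an amine on that aromatic carbon, with no sulfur at all.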